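A hexyl chain exchanged for a chlorobenzyl arm

This account rests on a few compounds, and the source may have more. Where it says the series, first, only, none or still open, it means among the compounds named here.

The series is built on a shared core in which a tetrazolylmethyl group and a second substituent sit on a nitrogen attached to an aromatic ring. Compound 1 `CCCCCCN(Cc1nnn[nH]1)c1ccccc1` carries a hexyl chain there, and in a physicochemical assay for lipophilicity, using the shake flask method, measured as octanol-water partition, with a stated time of 24 h, at 25 degrees C (a higher number here means a more lipophilic compound, a lower number a more polar compound), compound 1 gives 2.18, the highest of the three numbers measured. Compound 3 `Cc1ccc(N(Cc2nnn[nH]2)Cc2ccc(Cl)cc2Cl)cc1` gives 1.99, a number within the scatter of compound 1, while compound 2 `COc1ccc(N(Cc2nnn[nH]2)Cc2ccc(F)cc2F)cc1` gives 1.37, which lies beyond the scatter below compound 1.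

Compound 4 `Clc1ccccc1CN(Cc1nnn[nH]1)c1ccccc1` is not yet measured. It differs from compound 1 in one place: 2-chlorophenyl in place of pentyl on a saturated chain carbon bound to a nitrogen on an aromatic ring. Among the compounds with values here, no step between two measured compounds matches this change, so the expectation rests on compound 1 and the general run of the three values. The step in this assay from compound 1 to compound 4 is expected to be small, a number 0.18 log units lower from compound 1 to compound 4 (within the scatter), within the scatter or at most slightly downward. Compound 4 is therefore estimated at 2, with a range from 1.5 to 2.5.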

Compound 4, partition coefficient: 1.09
Beside the measured number, compound 4's estimate is 0.91 log units above it; the measured number lies below the stated range.
By their numbers in this assay, from the lowest: compounds 4 and 2 (each within the scatter of the next); then compounds 3 and 1 (each within the scatter of the next).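

In this assay, 2-chlorophenyl in place of pentyl on a saturated chain carbon bound to a nitrogen on an aromatic ring produces a large step, a number 1.09 log units lower from compound 1 to compound 4 (beyond the scatter) and beyond the scatter, so this position is clearly sensitive to the change. Within the data shown here, the earlier compounds offered no step that differed in one place, and this is the first to isolate the exchange of an open chain for a chlorine-bearing aromatic ring, even though the entering group has more heavy atoms than the one leaving. No measurement shown accounts for the size of this step.

Going by these compounds, whether the fall follows from the ring itself or from its chlorine remains open, and a plain phenyl in the same place would separate the two. It is also unknown how a longer chain or an amine at this position would compare with pentyl.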